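Purine-linked benzamide hydroxamate analogues: antiproliferative notes

The compounds below may be only part of what the source reports. "The series", "measured", "known", "first", "only" and "open" are said of these compounds alone.

Measured so far:
compound 1 `Nc1ccccc1NC(=O)/C=C/c1ccc(Cn2cnc3c(Nc4cccc(OC(F)(F)F)c4)nc(Cl)nc32)cc1` gives 37.6%
compound 2 `CCCCn1cnc2c(Nc3ccccc3)nc(NCOCc3ccc(/C=C/C(=O)Nc4ccccc4N)cc3)nc21` gives 59.3%
compound 3 `Nc1ccccc1NC(=O)c1ccc(Cn2cnc3c(Nc4cccc(OC(F)(F)F)c4)nc(Cl)nc32)cc1` gives 31.2%

All three compounds were read in a functional assay on HepG2 cells (Homo sapiens) for antiproliferative activity, read by CCK-8 assay, with a stated time of 72 h, tested at 8 uM; a higher number here means a stronger effect of the compound at the concentration tested, a lower number a weaker effect. Compound 2 stands highest of the three, and both gaps to it, to compound 1 and to compound 3, lie beyond the scatter. The difference between the core of compound 2 and the core of compound 1 is not broken down here; they differ in more than one place.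

One structural change is seen twice in the series. From compound 1 to compound 3 it is (2-aminophenyl)carbamoyl in place of 2-((2-aminophenyl)carbamoyl)ethenyl on an aromatic carbon, and the step it made in this assay was a number 6.4 percentage points lower from compound 1 to compound 3 (within the scatter). The same change, from compound 2 to the not yet measured compound 4 `CCCCn1cnc2c(Nc3ccccc3)nc(NCOCc3ccc(C(=O)Nc4ccccc4N)cc3)nc21`, is (2-aminophenyl)carbamoyl in place of 2-((2-aminophenyl)carbamoyl)ethenyl on an aromatic carbon, at a place described in the same words, so it is the same change on a different core.

Among the compounds with values here, for compound 4 a step of about a number 6.3 percentage points lower from compound 2 to compound 4 (within the scatter) is expected, close to the earlier one, resting on the single precedent that the step from compound 1 to compound 3 stayed within the scatter, and on the value of compound 2 as the starting point. Within the data shown here, compound 4 is therefore estimated at 53% in this assay, with a likely range from 40% to 66%; the pair compound 1 and compound 3 is the only guide, so the range is kept wide.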

Compound 4, a percentage reported as inhibition, at one concentration (the size of the read-out at that concentration, not a potency): 70.7%
Estimate against measurement, compound 4: 17.7 percentage points below, outside the stated range (above it).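

In this assay, (2-aminophenyl)carbamoyl in place of 2-((2-aminophenyl)carbamoyl)ethenyl gives a number 11.4 percentage points higher from compound 2 to compound 4 (beyond the scatter). Within the data shown here, this change therefore does not carry from one core to the other as a fixed step, and its outcome depends on the core that carries it: the same change on two cores in this assay, a number 6.4 percentage points lower (within the scatter) from compound 1 to compound 3 and a number 11.4 percentage points higher (beyond the scatter) from compound 2 to compound 4, 17.8 percentage points apart, beyond the scatter of two such steps This rests on only two pairs, so it does not show which of the several differences between the two cores matters, nor does it give a rule for any further core, and the read-out at one concentration says nothing about potency.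

Still open, as far as these compounds go, is how the change behaves when the two cores are altered one place at a time, for instance with the butyl chain replaced by a longer chain on an otherwise unchanged core of compound 2 and compound 4. Also open, from the compounds shown here alone, is whether a hydroxamic acid or a carboxylic acid in place of (2-aminophenyl)carbamoyl, on an aromatic carbon of the same six-membered aromatic ring, would follow compound 4 or take a different course on each core.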